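Methyl in place of furan-2-yl: working notes

A few compounds are considered here, and "the series" means these few. Any claim that something is new, unique, unknown or untested is made for them only; others in the source may bear on it.

Values in a functional assay on HCT-116 cells (Homo sapiens), read by MTT assay, with a stated time of 3 days (a higher number here means a weaker inhibitor, a lower number a stronger inhibitor), so far
Compound 1 `CN(C)c1ncnc2[nH]cc(Sc3cccs3)c12` gives 11000 nM
Compound 2 `c1coc(-c2ncnc3[nH]cc(Sc4cccs4)c23)c1` gives 6750 nM
Compound 3 `Cc1ncnc2[nH]cc(Sc3cccs3)c12` is still to be measured

Compound 2 and compound 1 stand within the scatter of each other, so these two numbers give no ranking. The next change leads to compound 3, with methyl in place of furan-2-yl on an aromatic carbon. Going by the values given here, one measured step bears on it (a 1.6-fold lower number from compound 1 to compound 2 (0.21 log units; within the scatter)), which put furan-2-yl in place of dimethylamino on an aromatic carbon and stayed within the scatter. Among the compounds with values here, no measured compound carries methyl, so the guide is thin. Resting on compound 2 at 6750 nM and on that one step, no change beyond the scatter is expected in this assay (a 1.2-fold higher number from compound 2 to compound 3 (0.07 log units; within the scatter)). For compound 3 the estimated value is 8000 nM (expected range 3500 nM to 20000 nM).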

Compound 3, half-maximal inhibitory concentration: 38100 nM
Compound 3: middle estimate off by 4.8-fold (0.68 log units), on the low side; measured number outside the range, above it.
By their numbers in this assay, from the lowest: compounds 2 and 1 (each within the scatter of the next); then compound 3.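

In this assay this position turns out to be able to move the number: the change gives a 5.6-fold higher number from compound 2 to compound 3 (0.75 log units; beyond the scatter) and, against the other measured group, a 3.5-fold higher number from compound 1 to compound 3 (0.54 log units; beyond the scatter) while furan-2-yl and dimethylamino stay within the scatter of each other. Of the three groups on this aromatic carbon, methyl alone stands apart, on the weaker side, so the group here is not interchangeable. Nothing measured accounts for the shift.

Still open, from the compounds shown here alone, is whether a phenyl ring or a primary amine at this carbon would stay with furan-2-yl and dimethylamino or fall with methyl. An ethyl chain would show whether a single added carbon is already enough to recover the lost ground.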